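Para-substituent swap on the 4-fluorophenyl compound

The compounds below may be only part of what the source reports. "The series", "measured", "known", "first", "only" and "open" are said of these compounds alone.

Values in a functional assay on KB cells (Homo sapiens) for inhibition, with a stated time of 72 h (on this read-out higher numbers stand for weaker inhibition and lower numbers for stronger inhibition), for the measured compounds:
compound 1 `COc1ccc(S(=O)(=O)N2CCc3cccc(-c4ccco4)c32)cc1` gives 82 nM
compound 2 `COc1ccc(S(=O)(=O)N2CCc3cccc(-c4ccc([N+](=O)[O-])cc4)c32)cc1` gives 52.5 nM
compound 3 `COc1ccc(S(=O)(=O)N2CCc3cccc(-c4ccc(F)cc4)c32)cc1` gives 86 nM

Compound 3 at 86 nM lies within the scatter of both other compounds, so the three values cannot be ranked. The next compound is compound 4 `COc1ccc(-c2cccc3c2N(S(=O)(=O)c2ccc(OC)cc2)CC3)cc1`, with methoxy in place of fluoro on an aromatic carbon, para to a large group (methoxy in place of fluoro on an aromatic carbon).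

The closest measured change is a 1.6-fold higher number from compound 2 to compound 3 (0.21 log units; within the scatter) with fluoro in place of nitro on an aromatic carbon. Replacing furan-2-yl gave a 1.6-fold lower number from compound 1 to compound 2 (0.19 log units; within the scatter) with 4-nitrophenyl and a 1.0-fold higher number from compound 1 to compound 3 (0.02 log units; within the scatter) with 4-fluorophenyl. All three steps stay within the scatter, though three compounds are a thin basis, and none of them carries methoxy. No shift in either direction beyond the scatter is therefore expected in this assay for this change. An estimated 1.2-fold lower number from compound 3 to compound 4 (0.09 log units; within the scatter) is expected to remain within the scatter. Compound 4 is expected at 70 nM (estimated range 30 nM to 170 nM).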

Compound 4, half-maximal inhibitory concentration: 337 nM
Estimate against measurement, compound 4: 4.8-fold (0.68 log units) below, outside the stated range (above it).
By their numbers in this assay, from the lowest: compounds 2, 1 and 3 (each within the scatter of the next); then compound 4.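

In this assay, within the data shown here, this place on the six-membered aromatic ring proves sensitive to the choice of group: methoxy in place of fluoro gives a 3.9-fold higher number from compound 3 to compound 4 (0.59 log units; beyond the scatter) and so moves beyond the scatter, which no earlier step did. The same holds against the other two compounds, with a 6.4-fold higher number from compound 2 to compound 4 (0.81 log units; beyond the scatter) for methoxy in place of nitro and a 4.1-fold higher number from compound 1 to compound 4 (0.61 log units; beyond the scatter) for 4-methoxyphenyl in place of furan-2-yl, leaving compound 4 apart from three compounds that stay within the scatter of each other. Nothing at hand explains why methoxy separates from fluoro and nitro here.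

From the compounds shown here alone, whether an amine or a hydroxyl at this place would sit with compound 3 or with compound 4 remains open. Also open is whether a longer chain such as ethoxy would take the number higher still, since methoxy is the only ether group shown.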